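This account rests on a few compounds, and the source may have more. Where it says the series, first, only, none or still open, it means among the compounds named here.

In a functional assay on J774 cells (Mus musculus) for cytotoxicity, read by resazurin assay (on this read-out lower numbers stand for stronger inhibition and higher numbers for weaker inhibition), three compounds sharing one core have been measured: compound 1 `CSc1ccc(-c2ccc(C(O)CCCCCO)cc2)cc1` gives 24000 nM, compound 2 `OCCCCCC(O)c1ccc(-c2ccc(C(F)(F)F)cc2)cc1` gives 13000 nM, and compound 3 `OCCCCCC(O)c1ccc(-c2ccc(OC(F)(F)F)cc2)cc1` gives 14000 nM. The value of compound 3 lies within the usual scatter of both others. Compound 4 `CCOc1ccc(-c2ccc(C(O)CCCCCO)cc2)cc1` differs from compound 3 by ethyl in place of trifluoromethyl on an oxygen on an aromatic ring, so trifluoromethoxy becomes ethoxy. The measured swaps of this group give a 1.1-fold higher number from compound 2 to compound 3 (0.03 log units; within the scatter), a 1.8-fold lower number from compound 1 to compound 2 (0.27 log units; within the scatter) and a 1.7-fold lower number from compound 1 to compound 3 (0.23 log units; within the scatter), and all three stayed within the scatter. For the measured compounds named here, no measured compound carries ethoxy, so this guide is indirect. An estimated step of a 1.1-fold higher number from compound 3 to compound 4 (0.06 log units; within the scatter) is expected, which is nothing beyond the scatter. For compound 4 the expected value is 16000 nM, with an estimated range from 8000 nM to 30000 nM.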

Compound 4, half-maximal inhibitory concentration: 14000 nM
Beside the measured number, compound 4's estimate is 1.1-fold (0.06 log units) above it; the measured number falls inside the stated range.
By their numbers in this assay, from the lowest: compounds 2, 3, 4 and 1 (each within the scatter of the next).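

In this assay, ethyl in place of trifluoromethyl on the oxygen gives no change at the digits printed from compound 3 to compound 4 (within the scatter) and so removes all the fluorine from this group without moving the result beyond the scatter. Ethoxy also reads like the other two groups, with a 1.1-fold higher number from compound 2 to compound 4 (0.03 log units; within the scatter) and with a 1.7-fold lower number from compound 1 to compound 4 (0.23 log units; within the scatter), so all four compounds remain alike in this assay whether or not the group carries fluorine. No supporting data bear on why these numbers sit so close. Still open, as far as these compounds go, is whether an amine or a carboxylic acid on this aromatic carbon, or a longer chain on the oxygen, would shift the number beyond the scatter.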